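Removing the chloro group from compound 2

A few compounds are considered here, and "the series" means these few. Any claim that something is new, unique, unknown or untested is made for them only; others in the source may bear on it.

Values so far in a physicochemical assay for lipophilicity, read by LC-MS, in phosphate buffer, measured as octanol-water partition, at pH 7.4, tested at 66.7 uM (on this read-out lower numbers stand for lower lipophilicity and higher numbers for higher lipophilicity), for two compounds:
- Compound 1 `Cc1ccc(-c2ccnc(Nc3ccc(N4CCN(C)CC4)c(C(F)(F)F)c3)n2)cc1` gives > 5.85 as a limit
- Compound 2 `CN1CCN(c2ccc(Nc3nccc(-c4cccc(Cl)c4)n3)cc2C(F)(F)F)CC1` gives > 6 as a limit

Compound 2 stands at > 6 and this is a limit, not a number. The change to compound 3 `CN1CCN(c2ccc(Nc3nccc(-c4ccccc4)n3)cc2C(F)(F)F)CC1` is hydrogen in place of chloro on an aromatic carbon and reads 3-chlorophenyl to phenyl. Among the measured compounds shown here, the only measured step that touches this group is a step that the two limits leave unreadable from compound 1 to compound 2 and it offers no size to carry over. The expected step in this assay is downward and is estimated as a number at least 0.40 log units lower from compound 2 to compound 3 (beyond the scatter) by this reckoning. Compound 3 is expected at 5.6 with a range from 5.1 to 6.1 on this estimate.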

Compound 3, distribution coefficient: 4.8
Estimate against measurement, compound 3: 0.80 log units above, outside the stated range (below it).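

In this assay compound 3 gives 4.8, the first reading shown that is a number and not a limit. Hydrogen in place of chloro on the aromatic carbon gives a number at least 1.20 log units lower from compound 2 to compound 3 (beyond the scatter), and hydrogen in place of methyl gives a number at least 1.05 log units lower from compound 1 to compound 3 (beyond the scatter). Both steps are large, so either group, set against the bare phenyl, marks a clear difference on this read-out.

From the compounds shown here alone, the full size of the step from the chloro compound stays open because compound 2 stands at a limit: the limit of > 6 in this assay, at which 1 of the 3 values shown sits. What a methoxy group or an amine on this ring would read also stays open.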